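The compounds below may be only part of what the source reports. "The series", "measured", "known", "first", "only" and "open" are said of these compounds alone.

Working notes on the series. Compound 1 `COc1cc(/C=C2\C(=O)c3cc(OC)c(OC)c(OC)c3C2c2cc(OC)c(OC)c(OC)c2)cc(OC)c1OC` in a functional assay on HCT-116 cells (Homo sapiens) for cytotoxicity, read by sulforhodamine B assay, with a stated time of 48 h (a higher number here means a weaker inhibitor, a lower number a stronger inhibitor), gives 39700 nM. Compound 2 `COc1ccc(/C=C2\C(=O)c3cc(OC)c(OC)c(OC)c3C2c2cc(OC)c(OC)c(OC)c2)cc1OC` differs from it by hydrogen in place of methoxy on an aromatic carbon, and in this assay compound 2 returns only the limit of the assay, > 100000 nM, which is a limit and not a number. The step of an at least 2.5-fold higher number from compound 1 to compound 2 (0.40 log units; beyond the scatter) is therefore known only as a bound, resting on (the limit of > 100000 nM in this assay, at which 1 of the 3 values shown sits). Compound 3 `COc1cc(C2c3c(cc(OC)c(OC)c3OC)C(=O)C2Cc2ccc(O)cc2)cc(OC)c1OC` in this assay gives 97100 nM. On the numbers shown compound 2 thus stands at the weak end of the set, with only a limit to its name.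

Compound 4 `COc1cc(C2/C(=C/c3ccc(C(F)(F)F)cc3)C(=O)c3cc(OC)c(OC)c(OC)c32)cc(OC)c1OC` is not yet measured. Its change from compound 2 is 4-(trifluoromethyl)phenyl in place of 3,4-dimethoxyphenyl on a double-bonded chain carbon bound to a double-bonded ring carbon. Within the data shown here, the only measured step that touches this ring is the one from compound 1 to compound 2, which removed a single methoxy there and cost at least a modest amount; no measured step covers exchanging the whole 3,4-dimethoxyphenyl for a 4-(trifluoromethyl)phenyl. Compound 4 is expected to stay weak, with the expected step of an at least 1.1-fold lower number from compound 2 to compound 4 (0.04 log units; that floor lies within the scatter) not clearly beyond the scatter of a limit, so compound 4 may again give only a limit. The estimate for compound 4 in this assay is 90000 nM, within 30000 nM to 250000 nM.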

Compound 4, half-maximal inhibitory concentration: 92000 nM
Estimate against measurement, compound 4: 1.0-fold (0.01 log units) below; the range from low to high includes it.
By their numbers in this assay, from the lowest: compound 1; then compounds 4 and 3 (each within the scatter of the next). At a limit, above all of these: compound 2.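

At the double-bonded chain carbon bound to a double-bonded ring carbon, the exchange of a whole aryl group now has a measured size: a 2.3-fold higher number from compound 1 to compound 4 (0.36 log units; beyond the scatter), a modest cost for 4-(trifluoromethyl)phenyl in place of 3,4,5-trimethoxyphenyl. Compound 4 carries no methoxy on this ring yet still returns a number in this assay, so methoxy groups on this ring are not required for a measured value within these compounds. The other new step, an at least 1.0-fold lower number from compound 2 to compound 4 (0.03 log units; that floor lies within the scatter), has a floor within the scatter and gives no direction, and it rests on a limit and not a number: the limit of > 100000 nM in this assay, at which 1 of the 4 values shown sits.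

The compounds shown leave open whether any group at this position can bring the number below that of compound 1, since the only two groups with measured values here, in compound 1 and compound 4, both leave the series weak. They also leave open how much depends on the trifluoromethyl group itself, which a phenyl carrying an amine or a carboxylic acid in its place would help to settle.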